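This account rests on a few compounds, and the source may have more. Where it says the series, first, only, none or still open, it means among the compounds named here.

Compound 1 `COc1cc(C)cc(-c2c(-c3ccnc(-c4ccc(C(C)=O)cc4)c3)cnn2CC#N)c1` gives 111% in a functional assay on TK-10 cells (Homo sapiens) for cytotoxicity, read by sulforhodamine B assay, with a stated time of 48 h, tested at 100 nM; on this read-out lower numbers stand for a stronger effect and higher numbers for a weaker effect at the one concentration tested; among the three measured compounds, compound 2 `Cc1cc(O)cc(-c2nn(CC#N)cc2-c2ccnc(-c3ccc(Oc4ccccc4)cc3)c2)c1` with 102% lies within the scatter of it, while compound 3 `Cc1cc(O)cc(-c2nn(CC#N)cc2-c2ccnc(-c3ccc(N(C)C)cc3)c2)c1` with 125% stands higher by a margin beyond the scatter. Compound 4 `COc1cc(C)cc(-c2c(-c3ccnc(-c4ccc(N(C)C)cc4)c3)cnn2CC#N)c1` is not yet measured; it differs from compound 1 by dimethylamino in place of acetyl on an aromatic carbon. For the measured compounds named here, one measured step bears on this change: a number 23 percentage points higher from compound 2 to compound 3 (beyond the scatter), where dimethylamino also entered, though in place of phenoxy rather than acetyl. Going by the values given here, because compound 3 with 125% is the only measured compound carrying dimethylamino, compound 4 is expected to move upward from compound 1 by a number 11 percentage points higher from compound 1 to compound 4 (beyond the scatter). Compound 4 is therefore estimated to give 122%, in a range from 105% to 140%.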

Compound 4, a percentage reported as activity, at one concentration (the size of the read-out at that concentration, not a potency): 44%
Beside the measured number, compound 4's estimate is 78 percentage points above it; the measured number lies below the stated range.
By their numbers in this assay, from the lowest: compound 4; then compounds 2 and 1 (each within the scatter of the next); then compound 3.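

Replacing 4-acetylphenyl with 4-(dimethylamino)phenyl gives a number 67 percentage points lower from compound 1 to compound 4 (beyond the scatter) in this assay, the first sign among these compounds that this position can carry a clear effect at the one concentration tested. Dimethylamino alone does not ensure this: compound 3 gives 125% with hydroxyl on the core where compound 4 has methoxy, so the outcome may depend on both places. No measurement shown here accounts for the lower number. On these data alone, what a primary amine or a morpholine ring would give at this position remains open, as does how compound 4 behaves at other concentrations.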